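The source may hold more compounds than are shown below. What is called first, only, known or untested is meant among the compounds shown, and "the series" means these compounds.

Measured compounds:
- compound 1, `COc1cc(-c2ccnc3cc(-c4ccc(Cl)cc4)nn23)cc(OC)c1OC`: in a functional assay on B16-F0 cells (Mus musculus) for inhibition, read by CCK-8 assay, with a stated time of 48 h (a higher number here means a weaker inhibitor, a lower number a stronger inhibitor), compound 1 gives 4090 nM.
- compound 2, `Cn1ccc2cc(-c3cc4nccc(-c5ccc(F)cc5)n4n3)ccc21`: in this assay compound 2 gives 4780 nM.
- compound 3, `Cc1ccc(-c2cc3nccc(-c4ccc(F)cc4)n3n2)cc1`: for compound 3 the result in this assay is only a limit, > 10000 nM, not a number.

Of the two compounds with a number, compound 1 has the lowest value, but its gap to compound 2 lies within the usual scatter, so the two cannot be told apart. The third result, for compound 3, is a limit of the assay the limit of > 10000 nM in this assay, at which 1 of the 3 values shown sits, and gives no number to compare.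

Compound 4, `COc1cc(-c2ccnc3cc(-c4ccc5c(ccn5C)c4)nn23)cc(OC)c1OC`, is the unmeasured compound. It comes from compound 1 by one change: 1-methyl-1H-indol-5-yl in place of 4-chlorophenyl on an aromatic carbon. The rest of compound 1 stays as it is. The 1-methyl-1H-indol-5-yl group that enters is also present in compound 2, whose value in this assay sits within the scatter of compound 1.

Among the measured compounds shown here, no measured step shows what this change does on the shared core. Since compounds 1 and 2 sit so close, the step in this assay is expected to stay within the scatter, with no clear direction. Compound 4 is therefore estimated at 3800 nM, in a range from 1300 nM to 11000 nM. The expected step is a 1.1-fold lower number from compound 1 to compound 4 (0.03 log units; within the scatter).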

Compound 4, half-maximal inhibitory concentration: 48 nM
Compound 4: middle estimate off by 79-fold (1.90 log units), on the high side; measured number below the stated range.
By their numbers in this assay, from the lowest: compound 4; then compounds 1 and 2 (each within the scatter of the next). At a limit, above all of these: compound 3.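

In this assay, this aromatic carbon of the five-membered ring proves highly sensitive to the group it carries: 1-methyl-1H-indol-5-yl in place of 4-chlorophenyl gives an 85-fold lower number from compound 1 to compound 4 (1.93 log units; beyond the scatter). The entering group does not give a low number on its own, however: compound 2 and compound 4 both carry it and differ in one other place, yet compound 4 gives 48 nM and compound 2 gives 4780 nM. The large step therefore appears with the rest of compound 4 in place, and nothing measured here tells why this group has such an effect on the core of compound 1.

The compounds shown leave open how much of the step belongs to the methyl group of 1-methyl-1H-indol-5-yl and how much to the two fused rings, a question that an indole with no methyl group could help to settle. As far as these compounds go, it also remains open whether a ring carrying an amine or a carboxylic acid at this aromatic carbon would keep a number as low as that of compound 4.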